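A few compounds are considered here, and "the series" means these few. Any claim that something is new, unique, unknown or untested is made for them only; others in the source may bear on it.

Measured compounds:
compound 1 `COc1ccc(-n2cnc3c(NC(C4CC4)C4CC4)nc(C)nc32)c(C)c1`, 47 nM
compound 2 `COCc1nc2c(NC(C3CC3)C3CC3)nc(C)nc2n1-c1ccc(OC)cc1`, 157 nM
compound 3 `Cc1nc(NC(C2CC2)C2CC2)c2nc(C)n(-c3ccc(C#N)cc3)c2n1`, 62 nM

In a functional assay on CHO cells for antagonist activity at corticotropin-releasing factor receptor 1 (Homo sapiens), read by cAMP accumulation (on this read-out lower numbers stand for stronger inhibition and higher numbers for weaker inhibition), compound 3 gives 62 nM. That places compound 3 second highest of the three numbers; compound 1 at 47 nM lies within the scatter of it, while compound 2 at 157 nM stands beyond it, higher. Compound 4 `Cc1nc(NC(C2CC2)C2CC2)c2nc(C)n(-c3ccc(OC(F)(F)F)cc3)c2n1` has not yet been measured. The change from compound 3 to compound 4 is trifluoromethoxy in place of cyano on an aromatic carbon. Going by the values given here, no measured pair in this set shows this change, so its effect is unknown here. Because compound 1 at 47 nM and compound 3 at 62 nM lie within the scatter of each other despite carrying different substituents, the expected step in this assay is small, with no direction beyond the scatter. Compound 4 is expected near 70 nM, ranging from 25 nM to 200 nM. The expected step is a 1.1-fold higher number from compound 3 to compound 4 (0.05 log units; within the scatter).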

Compound 4, inhibition constant: 9 nM
Estimate against measurement, compound 4: 7.8-fold (0.89 log units) above, outside the stated range (below it).
By their numbers in this assay, from the lowest: compound 4; then compounds 1 and 3 (each within the scatter of the next); then compound 2.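

Trifluoromethoxy in place of cyano on this aromatic carbon, para to a large group, gives a 6.9-fold lower number from compound 3 to compound 4 (0.84 log units; beyond the scatter) in this assay. Going by these compounds alone, this is the first pair here that differs in one place, so it is the first to show that the number in this assay depends on the group at this carbon. Nothing at hand explains the size of the step. On these data alone, how trifluoromethyl, a chlorine atom or an amine at this carbon would compare with trifluoromethoxy stays open. So does whether the same change would give a similar step in compound 2.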